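This account rests on a few compounds, and the source may have more. Where it says the series, first, only, none or still open, it means among the compounds named here.

Compound 1 `CC1=CC(=O)/C(=C(/C)Nc2ccc3cn(Cc4ccc(C)cc4)nc3c2)C(=O)O1` gives > 100000 nM in an ADME assay on RAW264.7 cells (Mus musculus) for cytotoxicity, read by resazurin assay, with a stated time of 48 h; on this read-out higher numbers stand for lower toxicity in this test and lower numbers for higher toxicity in this test; this value is a limit of the assay, not a number.
Compound 2 `CCn1nc2cc(N/C(C)=C3\C(=O)C=C(C)OC3=O)ccc2c1Cl` gives 6250 nM in this assay.

Compound 2 thus stands as the only one of the two with a measured number. Compound 1 instead sits at the limit of > 100000 nM in this assay, at which 1 of the 2 values shown sits.

Compound 3 `CC1=CC(=O)/C(=C(/C)Nc2ccc3c(Cl)n(Cc4ccc(C)cc4)nc3c2)C(=O)O1` has not been measured. It differs from compound 2 by 4-methylphenyl in place of methyl on a saturated chain carbon bound to an aromatic nitrogen. Among the measured compounds shown here, no pair of measured compounds shows this exact change, so its effect is not yet known from the data. Compound 1, however, carries the same 4-methylbenzyl group and reports only a limit, while compound 2 with ethyl reports a number. A step toward lower toxicity, beyond the usual scatter, is therefore expected a 6.4-fold higher number from compound 2 to compound 3 (0.81 log units; beyond the scatter). Compound 3 is estimated at 40000 nM, with a range from 10000 nM to 150000 nM.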

Compound 3, half-maximal cytotoxic concentration: > 100000 nM
Compound 3 was reported as a limit; the forecaster's own chance of this, stated with the estimate: 40%; middle value at least 2.5-fold (0.39 log units) from the limit.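

With the chloro group kept in place, 4-methylphenyl in place of methyl on a saturated chain carbon bound to an aromatic nitrogen gives, in this assay, an at least 16-fold higher number from compound 2 to compound 3 (1.20 log units; beyond the scatter). Among the compounds shown here, this is the first readable single change at this place, and it points to lower toxicity in this test, though compound 3 reports a limit and not a number, so the true size of the step remains unknown. The step between compound 1 and compound 3, which differ by chloro in place of hydrogen on an aromatic carbon, cannot be read, as both compounds share one limit: the limit of > 100000 nM in this assay, at which 2 of the 3 values shown sit.

As far as these compounds go, it remains open whether a propyl chain or a plain benzyl group would already raise the number. Also open, from the compounds shown here alone, is how an amine or a carboxylic acid on the benzyl ring would read in this assay.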